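The source may hold more compounds than are shown below. What is called first, only, known or untested is meant among the compounds shown, and "the series" means these compounds.

Going by the values given here, in a physicochemical assay for lipophilicity (a higher number here means a more lipophilic compound, a lower number a more polar compound), compound 3 `CCCCCCCCCCOc1ccc(-c2[nH]c3ccccc3c2C2=C(Br)C(=O)NC2=O)cc1` gives 5.94, the highest of the three values measured so far. Compound 2 `CCCCCOc1ccc(-c2[nH]c3ccccc3c2C2=C(Br)C(=O)NC2=O)cc1` gives 4.2 in this assay, and compound 1 `COc1ccc(-c2[nH]c3ccccc3c2C2=C(Br)C(=O)NC2=O)cc1` gives 2.42. All the steps between them are large and in the same direction: a number 1.78 log units higher from compound 1 to compound 2 (beyond the scatter); a number 1.74 log units higher from compound 2 to compound 3 (beyond the scatter); and a number 3.52 log units higher from compound 1 to compound 3 (beyond the scatter). Each step lengthens the chain on the oxygen by a saturated segment only.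

Compound 4 `O=C1NC(=O)C(c2c(-c3ccc(OCc4ccccc4)cc3)[nH]c3ccccc23)=C1Br` has not yet been measured in this assay. Its difference from compound 3 is phenyl in place of nonyl on a saturated chain carbon bound to an oxygen on an aromatic ring. This is not a further lengthening of the chain but an exchange of the nonyl for a group with fewer carbons arranged in one aromatic ring, so the measured steps bear on it only by way of their size: removing the nonyl would undo the whole of a number 3.52 log units higher from compound 1 to compound 3 (beyond the scatter), while the entering phenyl, with its six carbons, is expected to count back roughly as much as the single-segment steps a number 1.78 log units higher from compound 1 to compound 2 (beyond the scatter) and a number 1.74 log units higher from compound 2 to compound 3 (beyond the scatter). The step from compound 3 to compound 4 is therefore expected to be large and downward, about a number 1.74 log units lower from compound 3 to compound 4 (beyond the scatter). Compound 4 is expected to give 4.2 in this assay, with a range from 3.7 to 4.7.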

Compound 4, partition coefficient: 3.3
The estimate for compound 4 lay 0.90 log units above the measured number, and the stated range ends above it.
By their numbers in this assay, from the lowest: compound 1; then compound 4; then compound 2; then compound 3.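

In this assay, the exchange of nonyl for phenyl gives a number 2.64 log units lower from compound 3 to compound 4 (beyond the scatter) and so takes back most, but not all, of what the saturated chain added, while phenyl in place of hydrogen gives only a number 0.88 log units higher from compound 1 to compound 4 (beyond the scatter) and remains a modest step. Phenyl in place of butyl gives a number 0.90 log units lower from compound 2 to compound 4 (beyond the scatter) and so places the benzyloxy compound between the methoxy and pentyloxy compounds, which shows that at this position a count of carbons taken from the saturated chains does not carry over to an aromatic ring. The order in this series therefore no longer follows the size of the group alone, and nothing shown gives a measured reason for the place of compound 4.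

As far as these compounds go, it remains open whether this lower number belongs to the aromatic ring itself or to any ring on this carbon, a question that cyclohexyl in place of phenyl would address directly. Also open, from the compounds shown here alone, is how a phenyl carrying a further group, such as a carboxylic acid or an amine, or a pyridyl ring would read at the same place.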